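Propanoyl to bromoacetyl on the anilide of compound 1

The compounds below may be only part of what the source reports. "The series", "measured", "known", "first", "only" and "open" are said of these compounds alone.

Measured so far in a functional assay on KYSE-450 cells (Homo sapiens) for inhibition, read by MTT assay, with a stated time of 48 h; on this read-out lower numbers stand for stronger inhibition and higher numbers for weaker inhibition:
compound 1 `CCC(=O)N(Cc1ccc(OC)c(O)c1)c1cc(OC)c(OC)c(OC)c1`, 98 nM
compound 2 `COc1ccc(CNc2cc(OC)c(OC)c(OC)c2)cc1`, 4890 nM
compound 3 `COc1ccc(N(Cc2cc(OC)c(OC)c(OC)c2)C(=O)CCl)cc1O`, 29800 nM

Compound 1 stands lowest of the three numbers in this assay; compound 2 gives the nearest number and compound 3 the furthest, both beyond the scatter. Compound 2 lacks the acyl group on the nitrogen altogether, and compound 3 carries a chloroacetyl group on a core with the two aryl parts exchanged, so neither pair is a single-point comparison, and the two values say only that both arrangements sit far above compound 1.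

The next compound, compound 4 `COc1ccc(CN(C(=O)CBr)c2cc(OC)c(OC)c(OC)c2)cc1O`, keeps the core of compound 1 and changes only the acyl group: bromo in place of methyl on a saturated chain carbon bound to a carbonyl carbon.

Within the data shown here, no single-point step between measured compounds is available in this assay, so the size of the step can only be expected. The only other acyl variation seen, in compound 3 with 29800 nM, is entangled with the exchange of the aryl parts. A moderate loss beyond the scatter seems the more likely outcome, though retention of the number of compound 1 cannot be excluded.

Compound 4 is expected to give 350 nM, with a range of 70 nM to 2500 nM, which corresponds to an expected step of a 3.6-fold higher number from compound 1 to compound 4 (0.55 log units; beyond the scatter).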

Compound 4, half-maximal inhibitory concentration: 120 nM
The estimate for compound 4 lay 2.9-fold (0.46 log units) above the measured number, within the range that was stated.
By their numbers in this assay, from the lowest: compounds 1 and 4 (each within the scatter of the next); then compound 2; then compound 3.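

In this assay, among these compounds, the change of methyl to bromo on a saturated chain carbon bound to a carbonyl carbon gives a 1.2-fold higher number from compound 1 to compound 4 (0.09 log units; within the scatter) and is the first single-point step. On this read-out, the position on the core of compound 1 therefore takes either group without a difference that can be told apart from the usual scatter, so the number of compound 1 does not rest on the methyl end of the propanoyl group. No measurement at hand gives a reason for this equivalence or shows how either acyl group acts in the cells.

The compounds shown leave open whether chloro, hydroxy, dimethylamino or a longer chain such as butanoyl on the same carbon would stay within the scatter of compound 1. Also open, as far as these compounds go, is what removing the acyl group alone from the core of compound 1 would do, as compound 2 differs from compound 1 in more than one place and does not settle this.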